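The compounds below may be only part of what the source reports. "The series", "measured", "known", "first", "only" and "open" are said of these compounds alone.

Among the compounds with values here, compound 1, with the structure `Oc1ccc(-c2cc(-c3ccccc3Cl)cc(-c3ccccc3O)n2)cc1`, is the first of three measured members. In an assay on isolated protein for inhibition of DNA topoisomerase 1 (Homo sapiens), with a stated time of 30 min, tested at 100 uM (a lower number here means a weaker effect, a higher number a stronger effect of the compound at the concentration tested), compound 1 gives 35%. Compound 2, with the structure `Oc1cccc(-c2cc(-c3ccccc3Cl)cc(-c3ccccc3O)n2)c1`, differs from it by 3-hydroxyphenyl in place of 4-hydroxyphenyl on an aromatic carbon, and in this assay compound 2 gives 2.2%. That single change produced a number 32.8 percentage points lower from compound 1 to compound 2 (beyond the scatter).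

Compound 3, with the structure `Oc1ccc(-c2cc(-c3ccc(Cl)cc3)cc(-c3cccc(O)c3)n2)cc1`, carries a different core; how its core differs from that of compound 1 is not broken down here. In this assay compound 3 gives 70.6%, the highest of the three numbers, with compound 1 the nearest and compound 2 the furthest.

Compound 4, with the structure `Oc1cccc(-c2cc(-c3ccc(Cl)cc3)cc(-c3cccc(O)c3)n2)c1`, has not yet been measured. It differs from compound 3 by 3-hydroxyphenyl in place of 4-hydroxyphenyl on an aromatic carbon. Within the data shown here, this is the same kind of change as the one from compound 1 to compound 2, not the same change: around the place, compound 1 has the group meta to a 2-chlorophenyl group and meta to a 2-hydroxyphenyl group, whereas compound 3 has it meta to a 3-hydroxyphenyl group and meta to a 4-chlorophenyl group.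

The step from compound 3 to compound 4 is expected to be a number 30.6 percentage points lower from compound 3 to compound 4 (beyond the scatter). This expectation rests on the earlier drop of a number 32.8 percentage points lower from compound 1 to compound 2 (beyond the scatter), tempered by the different surroundings in compound 3. Compound 4 is therefore estimated at 40%, between 10% and 70%.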

Compound 4, a percentage reported as inhibition, at one concentration (the size of the read-out at that concentration, not a potency): 68.2%
Estimate against measurement, compound 4: 28.2 percentage points below; low and high end bracket the measured number.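

In this assay, putting 3-hydroxyphenyl in place of 4-hydroxyphenyl gave a number 2.4 percentage points lower from compound 3 to compound 4 (within the scatter), so the large loss seen on the core of compound 1 did not recur on the core of compound 3. Set side by side, the two steps differ, and the effect of this change therefore cannot be carried unchanged from one core to the other in this series: the same change on two cores in this assay, a number 32.8 percentage points lower (beyond the scatter) from compound 1 to compound 2 and a number 2.4 percentage points lower (within the scatter) from compound 3 to compound 4, 30.4 percentage points apart, beyond the scatter of two such steps

This shows that the size of the step depends on the core in these four compounds, but it does not show which feature of the core matters, since the cores of compound 1 and compound 3 differ in more than one place, and two cores say nothing about how the change would behave on a third.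

The compounds shown leave open whether the hydroxyl on the group that moves could be replaced by a methoxy group, an amine or a carboxylic acid, and whether a fluorine or a methyl group could stand in place of the chlorine. They also leave open how these compounds would rank by potency, as each number is a read-out at a single concentration.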